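The compounds below may be only part of what the source reports. "The series", "measured", "known", "first", "only" and "open" are said of these compounds alone.

Compound 2 `CN(C)CCn1cnnc1-c1cc(Oc2ccc(NC(=O)N/N=C/c3cccc(Cl)c3Cl)cc2F)ccn1` gives 51 nM in a functional assay on MKN-45 cells (Homo sapiens) for cytotoxicity, read by MTT assay, with a stated time of 72 h (a lower number here means a stronger inhibitor, a higher number a weaker inhibitor), the lowest of the three numbers recorded there. Compound 1 `CN(C)CCn1cnnc1-c1cc(Oc2ccc(NC(=O)N/N=C/c3cccc(O)c3)cc2F)ccn1` gives 1370 nM, and compound 3 `CN(C)CCn1cnnc1-c1cc(Oc2ccc(NC(=O)N/N=C/c3ccc(F)cc3)cc2F)ccn1` gives 1030 nM. Compound 4 `COc1ccc(/C=N/NC(=O)Nc2ccc(Oc3ccnc(-c4nncn4CCN(C)C)c3)c(F)c2)c(OC)c1` has not been measured; it differs from compound 2 in one place: 2,4-dimethoxyphenyl in place of 2,3-dichlorophenyl on a carbon with a double bond to nitrogen. Within the data shown here, two measured steps bear on this change, both at the carbon with a double bond to nitrogen: a 27-fold lower number from compound 1 to compound 2 (1.43 log units; beyond the scatter) and a 20-fold higher number from compound 2 to compound 3 (1.31 log units; beyond the scatter). Both other aryl groups tried there give far higher numbers than 2,3-dichlorophenyl, so a step to a higher number is expected for compound 4 as well. The step expected is a 9.8-fold higher number from compound 2 to compound 4 (0.99 log units; beyond the scatter). Compound 4 is estimated at 500 nM, with a range of 150 nM to 2000 nM.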

Compound 4, half-maximal inhibitory concentration: 1680 nM
Compound 4: the middle estimate sits 3.4-fold (0.53 log units) below what was measured; the measured number falls inside the stated range.
By their numbers in this assay, from the lowest: compound 2; then compounds 3, 1 and 4 (each within the scatter of the next).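

The step of a 33-fold higher number from compound 2 to compound 4 (1.52 log units; beyond the scatter) shows that in this assay the low number at this position does not carry over to 2,4-dimethoxyphenyl, another aryl group with two substituents. With a 1.6-fold higher number from compound 3 to compound 4 (0.21 log units; within the scatter) and a 1.2-fold higher number from compound 1 to compound 4 (0.09 log units; within the scatter), both within the scatter, three different aryl groups now give matching numbers, and compound 2 alone stands apart as the strongest. No measurement shown here explains this difference. As far as these compounds go, whether it follows the chlorine atoms or their placement remains open, and 2,3-dimethoxyphenyl and 2,4-dichlorophenyl would separate the two.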